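Methyl Addition on Two Acid Cores

This account rests on a few compounds, and the source may have more. Where it says the series, first, only, none or still open, it means among the compounds named here.

Measured so far:
compound 1 `Cc1[nH]c(C(F)(F)F)cc1C(=O)O`: 6700 nM
compound 2 `O=C(O)C1CCN(c2ccccc2)C1`: 48000 nM
compound 3 `O=C(O)c1c[nH]c(C(F)(F)F)c1`: only a limit, > 100000 nM

Compound 3 sits at the limit of > 100000 nM in this assay, at which 1 of the 3 values shown sits. Compound 1 differs from compound 3 by methyl in place of hydrogen on an aromatic carbon, and the step of an at least 14-fold lower number from compound 3 to compound 1 (1.17 log units; beyond the scatter). Compound 4 `Cc1cccc(N2CCC(C(=O)O)C2)c1` is not yet measured; it differs from compound 2 by methyl in place of hydrogen on an aromatic carbon. This is the same kind of change, not the same: in compound 1 the methyl sits on a five-membered aromatic ring with 1 nitrogen, next to the ring nitrogen, next to the ring atom that bears a carboxy group; in compound 4 it sits on a six-membered aromatic ring of carbon only, meta to a group of 8 heavy atoms. The difference between the two cores is not broken down here. In an assay on cells for inhibition of Palmitoleoyl-protein carboxylesterase NOTUM variant C330S (Homo sapiens), read by fluorescence, with a stated time of 40 min (on this read-out higher numbers stand for weaker inhibition and lower numbers for stronger inhibition), the step is expected to be smaller than the measured one, a 2.4-fold lower number from compound 2 to compound 4 (0.38 log units; beyond the scatter), resting only on that single measured step on a different core. Compound 4 is estimated at 20000 nM, between 6000 nM and 60000 nM.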

Compound 4, half-maximal inhibitory concentration: 49000 nM
Compound 4: middle estimate off by 2.5-fold (0.39 log units), on the low side; the range from low to high includes it.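

In this assay, methyl in place of hydrogen on an aromatic carbon gives a 1.0-fold higher number from compound 2 to compound 4 (0.01 log units; within the scatter). The change therefore does not carry a fixed effect from one core to the other, but two cores support no rule for the series and do not separate the core itself from the different place of the methyl: the same change on two cores in this assay, an at least 14-fold lower number (1.17 log units; beyond the scatter) from compound 3 to compound 1 and a 1.0-fold higher number (0.01 log units; within the scatter) from compound 2 to compound 4, at least 15-fold (1.18 log units) apart, beyond the scatter of two such steps
The value of compound 3, > 100000 nM, is a limit of the assay and not a number.

From the compounds shown here alone, it remains open whether a methoxy group or a chlorine atom in place of that hydrogen on compound 2 would behave as methyl does. Going by these compounds, the effect of an ethyl group on either core also remains open.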